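Working notes: blood half-life across the shared core

The source may hold more compounds than are shown below. What is called first, only, known or untested is meant among the compounds shown, and "the series" means these compounds.

Three measured compounds share one core and differ only in the aryl group on the carbonyl carbon of the ester. Compound 1 `COC(=O)CCNC(=O)[C@@H]1O[P@@](=O)(OCOC(=O)c2scnc2C(C)(C)C)OCC1(C)C` carries the 4-(tert-butyl)-1,3-thiazol-5-yl group. In an ADME assay on blood (Homo sapiens) for pharmacokinetics (a higher number here means that the compound lasts longer, a lower number that the compound disappears faster), compound 1 gives > 1 h, which is a limit of the assay and not a number. Compound 2 `COC(=O)CCNC(=O)[C@@H]1O[P@@](=O)(OCOC(=O)c2scnc2C)OCC1(C)C` carries the 4-methyl-1,3-thiazol-5-yl group. In this assay compound 2 gives > 1 h, again a limit rather than a number. Compound 3 `CCc1cc(C(=O)OCO[P@@]2(=O)OCC(C)(C)[C@H](C(=O)NCCC(=O)OC)O2)n(C)n1` carries the 3-ethyl-1-methyl-1H-pyrazol-5-yl group. In this assay compound 3 gives >= 0.97 h, also a limit. Where compound 3 stands can therefore only be told as a limit: the three values are bounded by the limit of > 1 h in this assay, at which 2 of the 3 values shown sit, and by the limit of >= 0.97 h in this assay, at which 1 of the 3 values shown sits. The steps a step that the two limits leave unreadable from compound 1 to compound 2, a step that the two limits leave unreadable from compound 1 to compound 3 and a step that the two limits leave unreadable from compound 2 to compound 3 cannot be sized.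

Compound 4 `COC(=O)CCNC(=O)[C@@H]1O[P@@](=O)(OCOC(=O)c2ccns2)OCC1(C)C` is not yet measured. Its difference from compound 3 is 1,2-thiazol-5-yl in place of 3-ethyl-1-methyl-1H-pyrazol-5-yl on a carbonyl carbon. Within the data shown here, none of the measured steps bears on this change with a readable size, so no step beyond the scatter is expected in either direction. The estimate for compound 4 in this assay is 1 h, expected between 0.5 h and 2 h. The step expected is a step that the limit leaves unreadable from compound 3 to compound 4, which is no change beyond the scatter.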

Compound 4, half-life: < 0.16 h
Compound 4: only a limit was reported (the forecaster's own chance of this, stated with the estimate: 70%); at least 6.2-fold (0.79 log units) between middle value and limit.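

In this assay, among these compounds, the group on the carbonyl carbon proves able to carry a step beyond the scatter, which the earlier compounds, all reported as limits, could not show: 1,2-thiazol-5-yl in place of 3-ethyl-1-methyl-1H-pyrazol-5-yl gives an at least 6.0-fold lower number from compound 3 to compound 4 (0.78 log units; beyond the scatter). The thiazole comparisons run the same way, with an at least 6.2-fold lower number from compound 2 to compound 4 (0.79 log units; beyond the scatter) and an at least 6.2-fold lower number from compound 1 to compound 4 (0.79 log units; beyond the scatter), so a sulfur-bearing five-membered aromatic ring does not by itself go with the low number, as compounds 1 and 2 also carry one and stay at their limits. The value of compound 4 is a limit, and compound 4 alone stands at the low end of the values shown: the limit of < 0.16 h in this assay, at which 1 of the 4 values shown sits.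

Going by these compounds, the steps among compounds 1, 2 and 3 cannot be read, and the steps to compound 4 give only a minimum size, so the full extent of the change remains unknown. The compounds shown also leave open whether the ring arrangement of 1,2-thiazol-5-yl or the lack of an alkyl group on the ring goes with the low number, a question that an unsubstituted 1,3-thiazol-5-yl group or a methyl group on the 1,2-thiazol-5-yl ring would separate.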